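Methoxy in place of chloro on the shared core

The compounds below may be only part of what the source reports. "The series", "measured", "known", "first", "only" and "open" are said of these compounds alone.

In a functional assay on SW480 cells (Homo sapiens) for antiproliferative activity, read by MTT assay, with a stated time of 48 h (a lower number here means a stronger inhibitor, a higher number a weaker inhibitor), compound 1 `CCCCC(CCO)n1cnc2c(OC)ncnc21` gives > 50000 nM as a limit of the assay and not a number. Among the measured compounds shown here, compound 2 `CCCCCCCCCCCC(CCO)n1cnc2c(Cl)ncnc21` gives 5290 nM in this assay and so holds the only actual number so far. Going to compound 3 `CCCCCCCCCCCC(CCO)n1cnc2c(OC)ncnc21` puts methoxy in place of chloro on an aromatic carbon and leaves the rest unchanged. For the measured compounds named here, no measured pair shows this change alone, so only a moderate weakening in this assay is expected, with a 2.3-fold higher number from compound 2 to compound 3 (0.36 log units; beyond the scatter) as the estimated shift. The estimate for compound 3 is 12000 nM with an expected range from 4000 nM to 40000 nM for the measurement.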

Compound 3, half-maximal inhibitory concentration: 9700 nM
For compound 3 the middle estimate is 1.2-fold (0.09 log units) above the measured one; low and high end bracket the measured number.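

Methoxy in place of chloro on an aromatic carbon, next to the ring nitrogen, gives a shift within the scatter in this assay (a 1.8-fold higher number from compound 2 to compound 3 (0.26 log units; within the scatter)). This position of the shared core therefore accepts either group with the long chain in place. The chain change, heptyl in place of hydrogen on a saturated chain carbon, gives a step beyond the scatter (an at least 5.1-fold lower number from compound 1 to compound 3 (0.71 log units; beyond the scatter)), but that size is only a bound, resting on a limit of the assay: the limit of > 50000 nM in this assay, at which 1 of the 3 values shown sits.

Going by these compounds, whether an amine at this position fits the same reading remains open. So does whether a longer chain moves the number further.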